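Replacing Phenyl with a Propenyl Chain at the Ring Amine

This account rests on a few compounds, and the source may have more. Where it says the series, first, only, none or still open, it means among the compounds named here.

Compound 3 `OC1CCN(Cc2ccccc2)CC1N1CCN(c2ccccc2)CC1` shares its core with compound 1 `OC1CN(Cc2ccccc2)CCC1N1CCN(c2ccccc2)CC1`. In an assay on PC-12 cells for displacement of a labelled ligand from vesicular acetylcholine transporter (Homo sapiens) (a lower number here means a stronger inhibitor, a higher number a weaker inhibitor), compound 3 gives only a limit, > 100 nM, and not a number, so it sits at the limit of > 100 nM in this assay, at which 1 of the 3 values shown sits. Compound 1 gives 57 nM in this assay. Compound 2 `CCN1CCC(N2CCN(c3ccccc3)CC2)C(O)C1` carries a methyl in place of the phenyl of compound 1 on a saturated chain carbon bound to an amine nitrogen in a ring. In this assay compound 2 gives only a limit, > 1000 nM, which is the limit of > 1000 nM in this assay, at which 1 of the 3 values shown sits. The step of an at least 17-fold higher number from compound 1 to compound 2 (1.24 log units; beyond the scatter) shows that losing the phenyl at this place costs a great deal of binding.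

The unmeasured compound 4 `C/C=C/CN1CCC(O)C(N2CCN(c3ccccc3)CC2)C1` differs from compound 3 by prop-1-en-1-yl in place of phenyl on a saturated chain carbon bound to an amine nitrogen in a ring; cut one bond further out, the change reads benzyl to but-2-en-1-yl. Going by the values given here, the only measured step that bears on it is an at least 17-fold higher number from compound 1 to compound 2 (1.24 log units; beyond the scatter), where the same phenyl was removed at the same kind of place. Prop-1-en-1-yl, like methyl, has no ring, so a weakening of similar size is expected, and a limit is the most likely report. Compound 4 is therefore estimated at 3000 nM, within 500 nM to 20000 nM. That expectation corresponds to a step that the limit leaves unreadable from compound 3 to compound 4.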

Compound 4, half-maximal inhibitory concentration: > 100 nM
Compound 4: a limit, no number (the forecaster's own chance of this, stated with the estimate: 70%); the middle value does not contradict the limit.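

In this assay compound 3 and compound 4 both give only limits and not numbers, so no step can be read between them. The compounds shown leave open whether benzyl or but-2-en-1-yl at this place gives the stronger binding, and how far the true value of either compound lies from its limit.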